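Replacing 4-methylpiperazin-1-yl in compound 3

A few compounds are considered here, and "the series" means these few. Any claim that something is new, unique, unknown or untested is made for them only; others in the source may bear on it.

Measured in a functional assay (Homo sapiens) for inhibition, read by sulforhodamine B assay, with a stated time of 3 days; on this read-out higher numbers stand for weaker inhibition and lower numbers for stronger inhibition:
compound 1 `CN(C)c1nc(N2CCNCC2)nc2nc(NCc3ccccc3)c(Cl)nc12` gives 5900 nM
compound 2 `CN(C)c1nc2nc(N3CCNCC3)nc(N(C)C)c2nc1Cl` gives > 20000 nM (a limit of the assay)
compound 3 `CN1CCN(c2nc(N3CCCC3)c3nc(Cl)c(NCc4ccccc4)nc3n2)CC1` gives 6500 nM

Compound 1 at 5900 nM and compound 3 at 6500 nM lie within the scatter of each other. Compound 2 gives no number, only a limit of the assay (> 20000 nM).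

Compound 4 `OCCNc1nc(N2CCCC2)c2nc(Cl)c(NCc3ccccc3)nc2n1` carries (2-hydroxyethyl)amino in place of the 4-methylpiperazin-1-yl of compound 3, on an aromatic carbon ((2-hydroxyethyl)amino in place of 4-methylpiperazin-1-yl on an aromatic carbon). Among the measured compounds shown here, the one measured step, an at least 3.3-fold higher number from compound 1 to compound 2 (0.53 log units; beyond the scatter), puts dimethylamino in place of benzylamino, a group that compound 4 keeps, so it bears only loosely here. For the measured compounds named here, no measured step touches 4-methylpiperazin-1-yl. The expectation therefore starts from compound 3 at 6500 nM and foresees no shift beyond the scatter in this assay, with a slightly higher number the likelier direction, and with wide uncertainty. The expected change is a 1.2-fold higher number from compound 3 to compound 4 (0.09 log units; within the scatter) (an estimate). Compound 4 is estimated at 8000 nM, with an expected range from 3000 nM to 18000 nM (estimated ends).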

Compound 4, half-maximal inhibitory concentration: 15200 nM
Compound 4: middle estimate off by 1.9-fold (0.28 log units), on the low side; the range from low to high includes it.
By their numbers in this assay, from the lowest: compounds 1 and 3 (each within the scatter of the next); then compound 4. At a limit, above all of these: compound 2.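

In this assay, the position between two ring nitrogen atoms proves sensitive to its substituent: (2-hydroxyethyl)amino in place of 4-methylpiperazin-1-yl gives a 2.3-fold higher number from compound 3 to compound 4 (0.37 log units; beyond the scatter). Among the compounds shown here, this is the first measured step at this position; the earlier step concerned the benzylamino group, which compound 3 and compound 4 both keep. Nothing measured in this set accounts for the weaker inhibition seen with the open chain.

Still open, from the compounds shown here alone, is whether the higher number follows from the loss of the six-membered ring or from the entry of the hydroxyl-bearing chain. A morpholin-4-yl ring, a plain ethylamino chain or a longer 3-hydroxypropylamino chain at this position would help to separate the two, and none of these stands among the compounds shown.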